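Ethoxy to Methoxy: a Small Trim, Little Change Expected

The source may hold more compounds than are shown below. What is called first, only, known or untested is meant among the compounds shown, and "the series" means these compounds.

Measured so far:
- Compound 1, `CCOc1cc([C@H]2SCC(=O)N2NC(=O)c2nccnc2N)ccc1O`. In an ADME assay on PANC-1 cells (Homo sapiens) for cytotoxicity, read by MTT assay, with a stated time of 5 days (a higher number here means a weaker inhibitor, a lower number a stronger inhibitor), compound 1 gives > 100 ug/mL, which is a limit of the assay rather than a number.
- Compound 2, `CCOc1cc([C@@H]2SCC(=O)N2NC(=O)c2cnc(C)cn2)ccc1O`. In this assay compound 2 gives > 100 ug/mL, again a limit rather than a measured number.

Going by the values given here, compound 2 therefore stands where every value so far stands: at the limit of > 100 ug/mL in this assay, at which 2 of the 2 values shown sit. Among the compounds with values here, neither compound gave a number inside the range of this assay, so no step between measured compounds can be sized, and there is nothing to say about which of the two is the stronger or weaker inhibitor.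

Compound 3, `COc1cc([C@@H]2SCC(=O)N2NC(=O)c2cnc(C)cn2)ccc1O`, keeps the whole of compound 2 except for one change: hydrogen in place of methyl on a saturated chain carbon bound to an oxygen on an aromatic ring, read one bond further out as ethoxy to methoxy. Such a trim is small, and the expectation is a step of no size beyond the usual scatter in this assay. Compound 3 is therefore expected to sit at 150 ug/mL (range 60 ug/mL to 400 ug/mL), with the estimated step that the limit leaves unreadable from compound 2 to compound 3 meaning that a limit rather than a number is again the most likely outcome.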

Compound 3, half-maximal inhibitory concentration: > 100 ug/mL
Compound 3: a limit, no number; the forecaster's own chance of this, stated with the estimate: 85%; the middle value lies beyond the limit too.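

No step can be read from compound 2 to compound 3, because each of these compounds gives a limit and not a number: the limit of > 100 ug/mL in this assay, at which 3 of the 3 values shown sit. The compounds shown leave open whether ethoxy and methoxy differ at all in this assay, and which change to the shared core, if any, would give a measurable value there.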